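Ring nitrogen swap in a diaryl urea series

The source may report more compounds than this note shows. Statements on the series, on what has been measured and on what is new or still open speak of the compounds shown alone.

The two measured compounds share a diaryl urea core. Compound 1 `O=C(Nc1ccc(-n2ncc3c(F)cccc32)cc1)Nc1ccc(Cl)c(C(F)(F)F)c1` gives 29500 nM in a functional assay on HepG2 cells (Homo sapiens) for cytotoxicity, read by MTT assay, with a stated time of 72 h (on this read-out higher numbers stand for weaker inhibition and lower numbers for stronger inhibition), while compound 2 `O=C(Nc1ccc(-n2ncc3ccccc32)cc1)Nc1ccc(Cl)c(C(F)(F)F)c1` gives 8000 nM. Within the data shown here, the only measured step, a 3.7-fold lower number from compound 1 to compound 2 (0.57 log units; beyond the scatter), came from a hydrogen in place of fluoro on an aromatic carbon. Among the measured compounds shown here, on these numbers compound 2 stands lowest of the two, with compound 1 as its only neighbour.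

Compound 3 `O=C(Nc1ccc(-n2ncc3ccncc32)cc1)Nc1ccc(Cl)c(C(F)(F)F)c1` has not been measured. It differs from compound 2 by a group of 9 heavy atoms (6 carbon, 3 nitrogen; one five-membered aromatic ring with 2 hetero atoms, one six-membered aromatic ring with 1 hetero atom) in place of a group of 9 heavy atoms (7 carbon, 2 nitrogen; one five-membered aromatic ring with 2 hetero atoms, one six-membered aromatic ring of carbon only), on an aromatic carbon, placed on an aromatic carbon of a six-membered aromatic ring of carbon only. For the measured compounds named here, no measured step touches a ring carbon turned into a ring nitrogen; the fluoro step does not bear on it. With nothing to anchor a direction, the expected step of a 1.3-fold higher number from compound 2 to compound 3 (0.10 log units; within the scatter) in this assay is small, likely within the scatter. Compound 3 is therefore estimated at 10000 nM, with a range from 4000 nM to 30000 nM.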

Compound 3, half-maximal inhibitory concentration: 16000 nM
The estimate for compound 3 lay 1.6-fold (0.20 log units) below the measured number, within the range that was stated.
By their numbers in this assay, from the lowest: compounds 2, 3 and 1 (each within the scatter of the next, the first and the last beyond it).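

In this assay, among these compounds, a ring nitrogen in place of a ring carbon in the 1H-indazol-1-yl group gives a 2.0-fold higher number from compound 2 to compound 3 (0.30 log units; within the scatter), so this change, on an aromatic carbon para to a large group, is the first at this position that does not move the number beyond the scatter. Measured against the fluoro-bearing group, the entering group gives a 1.8-fold lower number from compound 1 to compound 3 (0.27 log units; within the scatter), so compound 3 cannot be separated from either compound 1 or compound 2, although those two lie beyond the scatter of each other. No measurement shown here accounts for these results.

The compounds shown leave open whether a ring nitrogen at another ring atom would give a similar number. They also leave open whether a methoxy group or an amine on the six-membered ring of the entering group would move the number beyond the scatter.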